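A few compounds are considered here, and "the series" means these few. Any claim that something is new, unique, unknown or untested is made for them only; others in the source may bear on it.

Compound 1, `Nc1cc(N)c2nc(-c3ccccc3)c(Oc3ccc(Cl)c(Cl)c3)nc2c1`, gives 17000 nM in a functional assay on SF-268 cells (Homo sapiens) for inhibition, read by sulforhodamine B assay, with a stated time of 48 h; on this read-out lower numbers stand for stronger inhibition of growth and higher numbers for weaker inhibition of growth. Compound 2, `COc1ccc(Sc2nc3cc(N)cc(N)c3nc2-c2ccccc2)cc1`, shares that core and differs only where the aromatic carbon carries (4-methoxyphenyl)sulfanyl instead of 3,4-dichlorophenoxy. For compound 2 this assay reports only a limit, < 100000 nM, and no number. The step that the limit leaves unreadable from compound 1 to compound 2 therefore cannot be read, because of the limit of < 100000 nM in this assay, at which 1 of the 2 values shown sits. Compound 3, `Nc1cc(N)c2nc(-c3ccccc3)c(Oc3ccc(F)cc3)nc2c1`, is the next member: 4-fluorophenoxy in place of (4-methoxyphenyl)sulfanyl on an aromatic carbon. Among the compounds with values here, no measured step shows what a 4-fluorophenoxy group does here; the only complete number in this assay belongs to compound 1, whose 3,4-dichlorophenoxy group is also an aryl ether, and the step from compound 2 is unreadable. On that basis compound 3 is expected to return to roughly the level of compound 1, with an expected step that the limit leaves unreadable from compound 2 to compound 3 from compound 2. The estimate for compound 3 is 25000 nM, between 8000 nM and 100000 nM.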

Compound 3, concentration for 50% growth inhibition: 13800 nM
Compound 3: the middle estimate sits 1.8-fold (0.26 log units) above what was measured; the range from low to high includes it.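

With 4-fluorophenyl in place of 3,4-dichlorophenyl on the oxygen on an aromatic ring, this assay shows a 1.2-fold lower number from compound 1 to compound 3 (0.09 log units; within the scatter). Within the data shown here, this gives the first readable comparison at this position: within these two phenoxy compounds, exchanging the two chlorines for a single fluorine leaves the growth-inhibition number unchanged within the scatter. The step to compound 3 from the sulfanyl compound cannot be read, because compound 2 carries only a limit and no number: the limit of < 100000 nM in this assay, at which 1 of the 3 values shown sits.

From the compounds shown here alone, what the sulfur link does compared with the oxygen link therefore stays open, as does the separate effect of the methoxy group. Going by these compounds, it is also open whether an amine in place of the oxygen, or a carboxylic acid on the phenoxy ring, would move the number beyond the scatter.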